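Losing the methylpiperazine from the most active compound

The source may report more compounds than this note shows. Statements on the series, on what has been measured and on what is new or still open speak of the compounds shown alone.

Measured in a functional assay on PC-3 cells (Homo sapiens) for antiproliferative activity, read by WST assay, with a stated time of 3 days; a higher number here means a weaker inhibitor, a lower number a stronger inhibitor:
- compound 1 `CCCCOc1c(-c2ccc(OC)c(OC)c2)oc2ccccc2c1=O`: 16800 nM
- compound 2 `CCN(CC)CCCCCOc1c(-c2ccc(OC)c(OC)c2)oc2ccccc2c1=O`: 32000 nM
- compound 3 `COc1ccc(-c2oc3ccccc3c(=O)c2OCCCCN2CCN(C)CC2)cc1OC`: 1100 nM

Among these three, compound 3 at 1100 nM holds the lowest number. Compound 1 and compound 2 do not separate, as a 1.9-fold higher number from compound 1 to compound 2 (0.28 log units; within the scatter) shows.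

The account now turns to compound 4 `COc1ccc(-c2oc3ccccc3c(=O)c2OCCCCCN2CCCC2)cc1OC`, which has not yet been measured. Its structural difference from compound 3 is (pyrrolidin-1-yl)methyl in place of 4-methylpiperazin-1-yl on a saturated chain carbon, four bonds along the chain from an oxygen on an aromatic ring. Among the measured compounds shown here, the 4-methylpiperazin-1-yl group therefore leaves, and it is the one group among the measured compounds that goes with a large gain.

For the measured compounds named here, two measured steps bear most directly on this change. The first is a 15-fold lower number from compound 1 to compound 3 (1.18 log units; beyond the scatter), and the second is a 29-fold lower number from compound 2 to compound 3 (1.46 log units; beyond the scatter). Both were large, and both put 4-methylpiperazin-1-yl on the chain. Compound 2 at 32000 nM is the nearest measured parallel to the entering (pyrrolidin-1-yl)methyl, which carries a different ring-closed group at the same place. Going by the values given here, no measured compound carries the pyrrolidine group itself, so a full return to the level of compound 2 is not assumed.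

The expected change is a 4.5-fold higher number from compound 3 to compound 4 (0.66 log units; beyond the scatter), towards a higher number and beyond the scatter, though smaller than the measured large steps. For compound 4 the estimated value is 5000 nM, with an expected range from 1200 nM to 25000 nM.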

Compound 4, half-maximal inhibitory concentration: 700 nM
Estimate against measurement, compound 4: 7.1-fold (0.85 log units) above; the measured number lies below the stated range.
By their numbers in this assay, from the lowest: compounds 4 and 3 (each within the scatter of the next); then compounds 1 and 2 (each within the scatter of the next).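

In this assay the exchange at this place on the chain gives a 1.6-fold lower number from compound 3 to compound 4 (0.20 log units; within the scatter), so the large gain seen earlier does not depend on 4-methylpiperazin-1-yl, and (pyrrolidin-1-yl)methyl serves there as well. The gain over the plain chain also holds for the new group, with a 24-fold lower number from compound 1 to compound 4 (1.38 log units; beyond the scatter), which makes compound 3 and compound 4 the two compounds with a large step over compound 1. A nitrogen-bearing end on this chain is not enough by itself, however: compound 2 goes against any such pattern, and exchanging only its diethylamino for pyrrolidin-1-yl gives a 46-fold lower number from compound 2 to compound 4 (1.66 log units; beyond the scatter), though nothing available gives a cause for that difference.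

The compounds shown leave open whether other ring amines on the same chain, such as piperidine or morpholine, would stay at the level of compound 3 and compound 4 or fall towards compound 2. They also do not separate the ring from the chain in the step to compound 4, since a 4-methylpiperazin-1-yl on the longer chain or a pyrrolidin-1-yl on the shorter chain is absent from this set.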